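Swapping Fluoro for Bromo in Two Related Pairs

This account rests on a few compounds, and the source may have more. Where it says the series, first, only, none or still open, it means among the compounds named here.

Compound 1 `CCOc1ccc(F)cc1C(C)NC(=O)N(C)S(=O)(=O)c1ccc(C)cc1` and compound 2 `CCOc1ccc(Br)cc1C(C)NC(=O)N(C)S(=O)(=O)c1ccc(C)cc1` share one core and differ only by bromo in place of fluoro on an aromatic carbon. In a functional assay on thoracic aorta (Rattus norvegicus, strain Wistar), with a stated time of 15 min (a lower number here means that less compound is needed, a higher number that more compound is needed for the effect), compound 1 gives 7800 nM. In this assay compound 2 gives 28600 nM, and the step between them is a 3.7-fold higher number from compound 1 to compound 2 (0.56 log units; beyond the scatter). Compound 3 `CCOc1ccc(F)cc1C(C)NC(=O)NS(=O)(=O)c1ccccc1` is built on a different core; the difference between the two cores is not broken down here. In this assay compound 3 reaches only the limit of the assay, > 300000 nM, which is a limit and not a number. The line the limit of > 300000 nM in this assay, at which 1 of the 3 values shown sits, marks where that limit sits. Compound 4 `CCOc1ccc(Br)cc1C(C)NC(=O)NS(=O)(=O)c1ccccc1` has not yet been measured and differs from compound 3 by bromo in place of fluoro on an aromatic carbon, the same change as from compound 1 to compound 2, made at the same place. For compound 4 in this assay the expected step is a step that the limit leaves unreadable from compound 3 to compound 4, because the same change earlier gave a 3.7-fold higher number from compound 1 to compound 2 (0.56 log units; beyond the scatter). Compound 3 already sits at the limit. Compound 4 is therefore estimated at 800000 nM, between 300000 nM and 3000000 nM, and will most likely again be reported as a limit rather than a number.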

Compound 4, half-maximal effective concentration: > 300000 nM
Compound 4: a limit, no number; the forecaster's own chance of this, stated with the estimate: 85%; the middle value is on the limit's open side.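

No step can be read from compound 3 to compound 4 in this assay, since each gives a limit and not a number: the limit of > 300000 nM in this assay, at which 2 of the 4 values shown sit.

The compounds shown leave open whether bromo in place of fluoro changes the number on the core of compound 3 as it does on the core of compound 1.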